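Swapping the pyridyl cap for a plain phenyl

This account rests on a few compounds, and the source may have more. Where it says the series, first, only, none or still open, it means among the compounds named here.

Measured compounds:
Compound 1, `Nc1cc(Cc2ccn(-c3cccc(-c4ccccc4)c3)n2)c2nn[nH]c2n1`, gives 85 nM in an assay on isolated protein for inhibition of Myeloperoxidase (Homo sapiens), with a stated time of 10 min; on this read-out higher numbers stand for weaker inhibition and lower numbers for stronger inhibition.
Compound 2, `Nc1cc(Cc2ccn(-c3ccccn3)n2)c2nn[nH]c2n1`, gives 54 nM in this assay.

Both compounds share one core and differ only in the aromatic ring attached to the five-membered ring. On the two numbers available, compound 2 gives the lower one, but its gap to compound 1 lies within the scatter, so the two cannot be ranked against each other.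

Compound 3, `Nc1cc(Cc2ccn(-c3ccccc3)n2)c2nn[nH]c2n1`, has not yet been tested in this assay. It arises from compound 2 through a single change: phenyl in place of pyridin-2-yl on an aromatic nitrogen. Within the data shown here, no measured pair in this set shows what such a swap does, so the data give no guidance beyond the fact that two different caps in compound 1 and compound 2 landed within the scatter of each other.

For compound 3, a step within the scatter is expected, with no preferred direction, so its estimated value is 70 nM, in a range from 30 nM to 170 nM. The step expected from compound 2 is therefore a 1.3-fold higher number from compound 2 to compound 3 (0.11 log units; within the scatter).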

Compound 3, half-maximal inhibitory concentration: 55 nM
Estimate against measurement, compound 3: 1.3-fold (0.10 log units) above; measured number inside the range.
By their numbers in this assay, from the lowest: compounds 2, 3 and 1 (each within the scatter of the next).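

Putting phenyl in place of pyridin-2-yl on the aromatic nitrogen gives a 1.0-fold higher number from compound 2 to compound 3 (0.01 log units; within the scatter) in this assay, so the two numbers cannot be told apart, and the ring nitrogen and hydrogen-bond acceptor that leave with pyridin-2-yl make no readable difference in this pair. Compound 3 also allows a direct comparison with compound 1: hydrogen in place of phenyl on an aromatic carbon gives a 1.5-fold lower number from compound 1 to compound 3 (0.19 log units; within the scatter), so the second phenyl of compound 1 makes no readable difference either. No separate measurement is available to explain these results.

As far as these compounds go, it remains open whether a cyclohexyl ring or a short alkyl chain on that nitrogen would give a similar number. From the compounds shown here alone, it is also open whether an amine or a carboxylic acid on the phenyl would produce a step beyond the scatter.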